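The source may hold more compounds than are shown below. What is called first, only, known or untested is meant among the compounds shown, and "the series" means these compounds.

Among the compounds with values here, in a functional assay on Jurkat cells (Homo sapiens) (on this read-out lower numbers stand for stronger inhibition and higher numbers for weaker inhibition), compound 3 `Cc1ccc(C)c(CNC(=O)C(=O)N[C@@H](C)C(=O)N[C@@H](CC(=O)O)C(=O)COc2c(F)c(F)cc(F)c2F)c1` gives 11 nM, the lowest number of the three measured so far. By comparison, compound 1 `C[C@H](NC(=O)C(=O)Nc1cccnc1N(C)C)C(=O)N[C@@H](CC(=O)O)C(=O)COc1c(F)c(F)cc(F)c1F` gives 27 nM and compound 2 `C[C@H](NC(=O)C(=O)NCc1ccccc1F)C(=O)N[C@@H](CC(=O)O)C(=O)COc1c(F)c(F)cc(F)c1F` gives 207 nM. The next structure, compound 4 `C[C@H](NC(=O)C(=O)NCc1c(Cl)cccc1Cl)C(=O)N[C@@H](CC(=O)O)C(=O)COc1c(F)c(F)cc(F)c1F`, keeps the shared core and has 2,6-dichlorophenyl in place of 2,5-dimethylphenyl on a saturated chain carbon bound to an amide-type nitrogen.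

Within the data shown here, the closest precedent is a 19-fold lower number from compound 2 to compound 3 (1.27 log units; beyond the scatter), a large step from swapping one substituted phenyl for another at this same place. The read-out can therefore move a long way with this kind of change. The step of a 2.5-fold lower number from compound 1 to compound 3 (0.39 log units; beyond the scatter) is smaller, but it also leaves compound 3 lowest. Among the measured compounds shown here, no measured compound carries chlorine, so the direction rests on compound 3 sitting at the low end of the range seen so far, and a modest move upward seems most likely. The expected change is a 3.6-fold higher number from compound 3 to compound 4 (0.56 log units; beyond the scatter). For compound 4, the estimated value is 40 nM, with an expected range from 10 nM to 160 nM.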

Compound 4, half-maximal inhibitory concentration: 110 nM
Beside the measured number, compound 4's estimate is 2.8-fold (0.44 log units) below it; the measured number falls inside the stated range.
By their numbers in this assay, from the lowest: compound 3; then compound 1; then compounds 4 and 2 (each within the scatter of the next).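

In this assay, within the data shown here, 2,6-dichlorophenyl is the first chlorine-bearing group seen at this place, and replacing 2,5-dimethylphenyl with it gives a 10-fold higher number from compound 3 to compound 4 (1.00 log units; beyond the scatter), so a second substituted phenyl group also fails to match the low number of compound 3. The other two steps place the new group: a 1.9-fold lower number from compound 2 to compound 4 (0.27 log units; within the scatter) leaves it level with 2-fluorophenyl, while a 4.1-fold higher number from compound 1 to compound 4 (0.61 log units; beyond the scatter) shows that it also falls short of the 2-(dimethylamino)pyridin-3-yl group on the amide-type nitrogen. Among the three benzyl compounds, the two carrying halogens, compounds 2 and 4, therefore stand together, apart from dimethyl-bearing compound 3, but nothing available explains this difference.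

A 2,6-dimethylbenzyl or 2,5-dichlorobenzyl group would help separate the effect of the kind of substituent from that of its placement. As far as these compounds go, how a benzyl group carrying an amine or a carboxylic acid would compare also remains open.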